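The source may report more compounds than this note shows. Statements on the series, on what has been measured and on what is new or still open speak of the compounds shown alone.

Measured compounds in a functional assay on HeLa cells (Homo sapiens) for cytotoxicity, read by MTT assay, with a stated time of 48 h; a lower number here means a stronger inhibitor, a higher number a weaker inhibitor:
- compound 1 `CCN(CC)c1ccc2cc(C(=O)c3ccc(N4CCN(S(=O)(=O)c5ccc(Br)cc5)CC4)cc3)oc2c1`; compound 1 gives > 40000 nM, which is a limit of the assay and not a number.
- compound 2 `CCOC(=O)N1CCN(c2ccc(C(=O)c3cc4ccc(N(CC)CC)cc4o3)cc2)CC1`; compound 2 gives 20300 nM.
- compound 3 `CCN(CC)c1ccc2cc(C(=O)c3ccc(N4CCN(S(=O)(=O)c5ccc(F)cc5)CC4)cc3)oc2c1`; compound 3 gives 21600 nM.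

Where compound 3 stands: of the two actual numbers in hand, compound 2 and compound 3 are separated only by a 1.1-fold higher number from compound 2 to compound 3 (0.03 log units; within the scatter), so neither can be set above the other. The remaining entry, that of compound 1, is a limit (the limit of > 40000 nM in this assay, at which 1 of the 3 values shown sits).

Compound 4 `CCN(CC)c1ccc2cc(C(=O)c3ccc(N4CCN(C(C)=O)CC4)cc3)oc2c1` differs from compound 3 by acetyl in place of (4-fluorophenyl)sulfonyl on an amine nitrogen in a ring. Among the measured compounds shown here, two measured steps concern the same ring nitrogen. The exchange a 1.1-fold higher number from compound 2 to compound 3 (0.03 log units; within the scatter) stays within the scatter. The exchange an at least 1.9-fold lower number from compound 1 to compound 2 (0.29 log units; that floor lies within the scatter) has a floor that itself lies within the scatter. Neither step gives grounds to expect the acetyl group to shift the read-out beyond the scatter, so the expected step of a 1.0-fold higher number from compound 3 to compound 4 (0.01 log units; within the scatter) is essentially flat. Compound 4 is therefore estimated at 22000 nM, with an expected range from 9000 nM to 50000 nM.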

Compound 4, half-maximal inhibitory concentration: 5150 nM
Compound 4: the middle estimate sits 4.3-fold (0.63 log units) above what was measured; measured number below the stated range.
By their numbers in this assay, from the lowest: compound 4; then compounds 2 and 3 (each within the scatter of the next). At a limit, above all of these: compound 1.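

In this assay, the ring nitrogen now shows a change beyond the scatter, and the smallest exchange is enough to produce it: a 3.9-fold lower number from compound 2 to compound 4 (0.60 log units; beyond the scatter), with methyl in place of ethoxy on a carbonyl carbon, alongside a 4.2-fold lower number from compound 3 to compound 4 (0.62 log units; beyond the scatter). A third step, an at least 7.7-fold lower number from compound 1 to compound 4 (0.89 log units; beyond the scatter), gives only a floor and adds no exact size. Compound 1 stands at a limit and not a number: the limit of > 40000 nM in this assay, at which 1 of the 4 values shown sits.

The compounds shown leave open whether a propionyl group, a longer acyl chain or a formyl group on this ring nitrogen would keep the lower number of compound 4. They also leave open how a methanesulfonyl group or an unsubstituted ring amine would read in this assay.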